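The compounds below may be only part of what the source reports. "The series", "measured", "known", "first", "only" and "open" are said of these compounds alone.

Measured so far in an ADME assay on microsomes from liver (Mus musculus) for metabolic stability, read by LC-MS, using NADPH, tested at 10 uM; a lower number here means that the compound disappears faster, a higher number that the compound lasts longer:
compound 1 `O=C(NCc1ccccc1)c1ccc(N2CCN(S(=O)(=O)c3cccc(Cl)c3Cl)CC2)nn1` gives 0.233 h
compound 2 `N#Cc1ncccc1S(=O)(=O)N1CCN(c2ccc(C(=O)NCc3ccc(F)cc3)[n+]([O-])n2)CC1` gives 0.267 h
compound 3 `O=C(NCc1ccc(F)cc1)c1ccc(N2CCN(S(=O)(=O)c3ccccc3C(F)(F)F)CC2)nn1` gives 0.517 h

Compound 3 has the highest of the three numbers; its gap to compound 2 lies within the scatter, its gap to compound 1 lies beyond it. Compound 4 `Cc1ccccc1S(=O)(=O)N1CCN(c2ccc(C(=O)NCc3ccc(F)cc3)nn2)CC1` has not yet been measured. It differs from compound 3 by methyl in place of trifluoromethyl on an aromatic carbon, the methyl sitting on an aromatic carbon of a six-membered aromatic ring of carbon only, ortho to a large group. Within the data shown here, no measured pair shows this change on its own, so its size is not known from these compounds. In this assay a step within the scatter is expected, if anything toward a lower number, a 1.5-fold lower number from compound 3 to compound 4 (0.17 log units; within the scatter). Compound 4 is therefore estimated at 0.35 h, between 0.15 h and 0.8 h.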

Compound 4, half-life: 0.433 h
For compound 4 the middle estimate is 1.2-fold (0.09 log units) below the measured one, and the stated range covers the measured number.
By their numbers in this assay, from the lowest: compounds 1, 2, 4 and 3 (each within the scatter of the next, the first and the last beyond it).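

Among these compounds, the pair gives the series its first single-place comparison in this assay, and the step of a 1.2-fold lower number from compound 3 to compound 4 (0.08 log units; within the scatter) is the only reading so far for 2-(trifluoromethyl)phenyl to 2-methylphenyl. On this aromatic carbon, ortho to a large group, methyl and trifluoromethyl cannot be told apart in this read-out, although the change removes three fluorine atoms. Nothing available explains this result.

As far as these compounds go, whether methoxy or an amine at this place would read the same stays open. So does whether this step would hold with another amide group on the shared core.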